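Notes on a chloro-for-hydrogen step, second occurrence

The compounds below may be only part of what the source reports. "The series", "measured", "known", "first", "only" and "open" are said of these compounds alone.

Of the compounds shown here, three in this set have been measured in a functional assay on OVCAR-5 cells (Homo sapiens) for cytotoxicity, read by sulforhodamine B assay, with a stated time of 48 h; on this read-out higher numbers stand for weaker inhibition of growth and lower numbers for stronger inhibition of growth. Compound 1 `ClCc1cccc(Cn2cnc3ncnc(Cl)c32)c1` gives 6760 nM. Compound 2 `ClCc1ccc(Cn2cnc3nc(Cl)nc(Cl)c32)cc1` gives 2180 nM in this assay, and compound 3 `ClCc1cccc(Cn2cnc3nc(Cl)nc(Cl)c32)c1` gives 1690 nM. The values of compound 2 and compound 3 lie within the scatter of each other, so nothing separates them on this read-out. Compound 1 stands apart: its number sits higher than that of compound 2 by a margin beyond the scatter, and the measured step of a 4.0-fold higher number from compound 3 to compound 1 (0.60 log units; beyond the scatter) is likewise beyond the scatter. That step goes with the structural change (hydrogen in place of chloro on an aromatic carbon).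

Compound 4 `ClCc1ccc(Cn2cnc3ncnc(Cl)c32)cc1` has not yet been measured in this assay. It is related to compound 2 by hydrogen in place of chloro on an aromatic carbon. The place descriptions of this change and of the change from compound 3 to compound 1 agree word for word, so the same change is made here a second time, on a second core. How the core of compound 2 differs from the core of compound 3 is not broken down here; their two values show only agreement within the scatter.

With a single prior instance, the expectation leans on it directly. Because compound 2 gives 2180 nM and the earlier step was a 4.0-fold higher number from compound 3 to compound 1 (0.60 log units; beyond the scatter), compound 4 is expected to move by a 4.0-fold higher number from compound 2 to compound 4 (0.60 log units; beyond the scatter) in this assay. Compound 4 is accordingly estimated at 8700 nM, with the likely range running from 3500 nM to 22000 nM.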

Compound 4, concentration for 50% growth inhibition: 6300 nM
The estimate for compound 4 lay 1.4-fold (0.14 log units) above the measured number, and the stated range covers the measured number.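

In this assay the new step is a 2.9-fold higher number from compound 2 to compound 4 (0.46 log units; beyond the scatter), and it runs the same way as the earlier step: hydrogen in place of chloro on an aromatic carbon, between two ring nitrogen atoms, goes with weaker inhibition of growth on both cores. The size of the step also carries from one core to the other, with no difference that can be told apart on this read-out: the same change on two cores in this assay, a 4.0-fold higher number (0.60 log units; beyond the scatter) from compound 3 to compound 1 and a 2.9-fold higher number (0.46 log units; beyond the scatter) from compound 2 to compound 4, 1.4-fold (0.14 log units) apart, within the scatter of two such steps

This rests on just two matched pairs on a single read-out, so it supports transfer between these two cores only and says nothing of a third core or of other cells, nor does it give any reason for the step.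

The compounds shown hold only chloro or hydrogen at this aromatic carbon, so it stays open how an amine, a methoxy group or a nitrile there would compare with either. Also open, going by these compounds, is whether the step would keep its size with the other chloro group on that ring replaced, or with a hydroxymethyl group in place of the chloromethyl group on the benzene ring.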